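The source may report more compounds than this note shows. Statements on the series, on what has been measured and on what is new or still open speak of the compounds shown alone.

Measured so far:
- compound 1, `Cc1ccccc1-n1c(Nc2nc(-c3ccc(Br)cc3)cs2)n[nH]c1=S`: 30 mg/kg
- compound 2, `Cc1ccc(-n2c(Nc3nc(-c4ccc(Cl)cc4)cs3)n[nH]c2=S)cc1`: 300 mg/kg

Both compounds were tested in a functional assay on the whole organism (strain Swiss albino) for inhibition, with Mus musculus as the target, with a stated time of 0.5 h; a lower number here means that less compound is needed, a higher number that more compound is needed for the effect. Compound 1 gives 30 mg/kg in this assay, while compound 2 gives 300 mg/kg. Among the compounds with values here, of these two numbers, compound 2 holds the higher one, and its only neighbour, compound 1, lies well below it, a gap beyond the usual scatter of this kind of measurement. The two compounds differ in more than one place, so no single change can be credited with that gap.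

Compound 3, `Cc1ccc(-n2c(Nc3nc(-c4ccc(Br)cc4)cs3)n[nH]c2=S)cc1`, has not yet been measured in this assay. It differs from compound 2 in one place only: bromo in place of chloro on an aromatic carbon. Within the data shown here, the change is small in count, a single heavy atom swapped for another of the same kind of role, and no step that isolates this change has been measured here. The expectation is therefore a step that stays within the scatter, with a slight lean toward a lower number; compound 3 is expected to give 200 mg/kg, with a range from 60 mg/kg to 600 mg/kg, which means an estimated step of a 1.5-fold lower number from compound 2 to compound 3 (0.18 log units; within the scatter).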

Compound 3, minimum effective dose: 100 mg/kg
Beside the measured number, compound 3's estimate is 2.0-fold (0.30 log units) above it, and the stated range covers the measured number.
By their numbers in this assay, from the lowest: compound 1; then compound 3; then compound 2.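

In this assay, bromo in place of chloro on the outer aromatic ring gives a 3.0-fold lower number from compound 2 to compound 3 (0.48 log units; beyond the scatter), so this position responds to the choice of halogen even though the change swaps only one heavy atom for another and adds no hydrogen-bond donors, hydrogen-bond acceptors or net charge. Compound 3 also connects the two earlier compounds, which differ in more than one place: 4-methylphenyl in place of 2-methylphenyl on the aromatic nitrogen gives a 3.3-fold higher number from compound 1 to compound 3 (0.52 log units; beyond the scatter), showing that where the methyl group sits on that ring also matters. The large gap first seen between compound 1 and compound 2 can therefore be read as two separate steps, one at each place, and each lies beyond the usual scatter.

No available measurement bears on why either step occurs. Also open, as far as these compounds go, is how a fluoro or methoxy group would compare at the place held by chloro and bromo, and whether bromo in place of chloro would give a similar step with 2-methylphenyl on the aromatic nitrogen.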